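Swapping the aniline for a carboxymethyl pyrazole

A few compounds are considered here, and "the series" means these few. Any claim that something is new, unique, unknown or untested is made for them only; others in the source may bear on it.

Of the compounds shown here, three sharing one core have been tested in a functional assay on MCF7 cells (Homo sapiens) for antiproliferative activity, read by sulforhodamine B assay, with a stated time of 72 h; a higher number here means a weaker inhibitor, a lower number a stronger inhibitor. Compound 1 `COc1ncc(-c2ccc3ncnc(Nc4ccc(OCCO)cc4)c3c2)cc1NS(=O)(=O)c1ccc(F)cc1F` gives 1650 nM in this assay. Among the measured compounds shown here, its close relative compound 3 `COc1ncc(-c2ccc3ncnc(Nc4ccc(OCCO)c(F)c4)c3c2)cc1NS(=O)(=O)c1ccc(F)cc1F` gives 4820 nM, and the only single-point step among the measured compounds, a 2.9-fold higher number from compound 1 to compound 3 (0.47 log units; beyond the scatter), shows that a fluoro on the aromatic ring of the aniline costs potency. For the measured compounds named here, compound 2 `COc1ncc(-c2ccc3ncnc(Nc4cnn(CCC(=O)O)c4)c3c2)cc1NS(C)(=O)=O` gives 560 nM; it differs from compound 1 in both the aniline part and the sulfonamide part, so no single step links the two, but its value is the lowest of the three and carries a pyrazole acid. Among the three numbers, compound 1 stands second highest, nearer to compound 3 than to compound 2.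

Compound 4 `COc1ncc(-c2ccc3ncnc(Nc4cnn(CC(=O)O)c4)c3c2)cc1NS(=O)(=O)c1ccc(F)cc1F` is not yet measured. It differs from compound 1 in one place, (1-(carboxymethyl)-1H-pyrazol-4-yl in place of 4-(2-hydroxyethoxy)phenyl on a nitrogen on an aromatic ring), while keeping the difluorophenylsulfonamide of compound 1. Going by the values given here, none of the measured steps covers this exact change; the fluoro step from compound 1 to compound 3 concerns a different part of the molecule. The comparison with compound 2, which also bears a pyrazole acid, is the only hint, and it points toward a lower number.

Compound 4 is therefore expected to give about 900 nM in this assay, within 300 nM to 3000 nM, meaning an expected step of a 1.8-fold lower number from compound 1 to compound 4 (0.26 log units; within the scatter).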

Compound 4, half-maximal inhibitory concentration: 700 nM
Compound 4: the middle estimate sits 1.3-fold (0.11 log units) above what was measured; measured number inside the range.
By their numbers in this assay, from the lowest: compounds 2 and 4 (each within the scatter of the next); then compound 1; then compound 3.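

The step of a 2.4-fold lower number from compound 1 to compound 4 (0.37 log units; beyond the scatter) in this assay shows that the group on this nitrogen can be exchanged whole, with 1-(carboxymethyl)-1H-pyrazol-4-yl replacing 4-(2-hydroxyethoxy)phenyl, and that the difluorophenylsulfonamide need not change for the number to fall beyond the scatter. Among the compounds shown here, until now the only single-place step at this position was the fluoro step, which raised the number, whereas the same replacement measured against the fluorinated aniline gives a 6.9-fold lower number from compound 3 to compound 4 (0.84 log units; beyond the scatter), the larger of the two new steps. No measurement shown here offers any explanation for either step.

Because the five-membered aromatic ring and the carboxylic acid enter together in one change, the compounds shown do not separate what each contributes, and a pyrazole carrying a simple methyl group, a primary amide or a hydroxyethyl chain on its nitrogen would be needed to tell them apart. They also leave open how a longer chain ending in the carboxylic acid behaves alongside the difluorophenylsulfonamide, as compound 2 differs from compound 4 in two places.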